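The compounds below may be only part of what the source reports. "The series", "measured", "known", "first", "only" and "open" are said of these compounds alone.

Working notes on the series in a functional assay on HEp-2 cells (Homo sapiens) for antiproliferative activity, read by MTT assay, with a stated time of 72 h; on this read-out lower numbers stand for stronger inhibition and higher numbers for weaker inhibition. Of the compounds shown here, two carry numbers so far. Compound 1 `O=c1c(CSC(=S)N2CCOCC2)coc2cc(Cl)ccc12` gives 900 nM in this assay. Among the measured compounds shown here, compound 2 `Cc1ccc2c(=O)c(CSC(=S)N3CCCC3)coc2c1` gives 3600 nM in this assay, the higher of the two numbers; the two compounds differ in more than one place, so the gap is not read as a single step, and it says only that compound 2 sits higher than compound 1 by a margin beyond the usual scatter.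

The next step goes from compound 2 to compound 3 `O=c1c(CSC(=S)N2CCCC2)coc2cc(Cl)ccc12`. The change is chloro in place of methyl on an aromatic carbon. Compound 3 keeps the rest of compound 2 unchanged and, at that aromatic carbon, now carries the same chloro that compound 1 carries.

For the measured compounds named here, no measured step of this exact kind exists, so the expected size rests on the two numbers in hand. Compound 1, at 900 nM, stands well below compound 2, at 3600 nM, and compound 3 shares the chloro of compound 1 while keeping the remainder of compound 2. The expectation for compound 3 is therefore a move toward compound 1, likely beyond the scatter but short of its number, with the estimated step from compound 2 to compound 3 in this assay being a 2.4-fold lower number from compound 2 to compound 3 (0.38 log units; beyond the scatter). For compound 3 the estimate in this assay is 1500 nM, within a range of 500 nM to 4500 nM.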

Compound 3, half-maximal inhibitory concentration: 2100 nM
Beside the measured number, compound 3's estimate is 1.4-fold (0.15 log units) below it; the measured number falls inside the stated range.
By their numbers in this assay, from the lowest: compound 1; then compounds 3 and 2 (each within the scatter of the next).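

In this assay, chloro in place of methyl on the aromatic carbon gives a 1.7-fold lower number from compound 2 to compound 3 (0.23 log units; within the scatter) with pyrrolidin-1-yl held fixed, so this step alone does not separate the two groups at this position. Among the compounds shown here, the change on the thiocarbonyl carbon, pyrrolidin-1-yl in place of morpholin-4-yl with chloro held fixed, gives a 2.3-fold higher number from compound 1 to compound 3 (0.37 log units; beyond the scatter) and is the only single-place step so far that lies beyond the scatter, although it is modest. No measured evidence on the compounds bears on why either step has the size it has.

Still open, from the compounds shown here alone, is whether chloro and methyl also remain within the scatter of each other with morpholin-4-yl on the thiocarbonyl carbon, and whether the step on that carbon keeps its size with methyl on the aromatic carbon. Also open, going by these compounds, is where a piperidin-1-yl or dimethylamino group on the thiocarbonyl carbon, or a methoxy group or carboxylic acid on the aromatic carbon, would stand.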